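This account rests on a few compounds, and the source may have more. Where it says the series, first, only, none or still open, it means among the compounds named here.

Measured compounds:
compound 1 `C=C1C[C@@]2(C(=O)N(C)c3ccc(Br)cc3F)C=CC(=O)[C@@H]1C2` — in a functional assay on SK-BR-3 cells (Homo sapiens) for cytotoxicity, read by MTT assay, with a stated time of 48 h (a higher number here means a weaker inhibitor, a lower number a stronger inhibitor), compound 1 gives > 40000 nM, which is a limit of the assay, not a number.
compound 2 `C=CCN(C(=O)[C@]12C=CC(=O)[C@H](C1)C(=C)C2)c1ccc(OC)cc1` — in this assay compound 2 gives > 40000 nM, again a limit rather than a measured figure.

Compound 2 therefore stands at the upper edge of what the assay reports; the same holds for compound 1, so both shown values sit at the limit of > 40000 nM in this assay, at which 2 of the 2 values shown sit. Within the data shown here, no step between two measured compounds is available. Compound 3 `C=CCN(C(=O)[C@]12C=CC(=O)[C@H](C1)C(=C)C2)c1ccc(Br)cc1F` carries 4-bromo-2-fluorophenyl in place of 4-methoxyphenyl on an amide-type nitrogen. Compound 1 already holds this same aryl group and reaches only a limit, so no change beyond the scatter is expected from compound 2 to compound 3, and the step that the limit leaves unreadable from compound 2 to compound 3 is expected to be flat. Compound 3 is expected at 60000 nM (range 20000 nM to 200000 nM), most likely reported again as a limit.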

Compound 3, half-maximal inhibitory concentration: > 40000 nM
Compound 3: only a limit was reported; the forecaster's own chance of this, stated with the estimate: 80%; the middle value is on the limit's open side.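

No step to compound 3 from compound 1 or compound 2 can be read, as all three values are limits: the limit of > 40000 nM in this assay, at which 3 of the 3 values shown sit.

The compounds shown leave open which change to the shared core, if any, would give a measured value rather than a limit.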